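Branched or Straight Chain on the Aryl Ether Oxygen

The source may report more compounds than this note shows. Statements on the series, on what has been measured and on what is new or still open speak of the compounds shown alone.

Measured in an assay on V79MZh11B2 cells for inhibition of cytochrome P450 11B2, mitochondrial (Homo sapiens), read by HPLC, with a stated time of 25 min; on this read-out higher numbers stand for weaker inhibition and lower numbers for stronger inhibition:
compound 1 `COc1ccc(COc2ccc3c(Cn4ccnc4)cc(=O)oc3c2)cc1` gives 124 nM
compound 2 `CC(C)Oc1ccc(COc2ccc3c(Cn4ccnc4)cc(=O)oc3c2)cc1` gives 82 nM

Compound 2 has the lowest of the two numbers, but its nearest neighbour is compound 1, and the step of a 1.5-fold lower number from compound 1 to compound 2 (0.18 log units; within the scatter) lies within the scatter, so the two cannot be put in order. Compound 3 `CCCOc1ccc(COc2ccc3c(Cn4ccnc4)cc(=O)oc3c2)cc1` has not yet been measured. It differs from compound 2 by propyl in place of isopropyl on an oxygen on an aromatic ring. Among the measured compounds shown here, the only measured step that bears on this change is a 1.5-fold lower number from compound 1 to compound 2 (0.18 log units; within the scatter), which altered the alkyl group on the same oxygen and stayed within the scatter. On that basis, no step beyond the scatter is expected from compound 2 to compound 3 in this assay, that is a 1.1-fold higher number from compound 2 to compound 3 (0.04 log units; within the scatter). Compound 3 is therefore estimated at 90 nM, with a range from 45 nM to 180 nM.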

Compound 3, half-maximal inhibitory concentration: 77 nM
Beside the measured number, compound 3's estimate is 1.2-fold (0.07 log units) above it, and the stated range covers the measured number.
By their numbers in this assay, from the lowest: compounds 3, 2 and 1 (each within the scatter of the next).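

In this assay, changing the branched isopropyl on this oxygen to the straight propyl gives a step that stays within the scatter (a 1.1-fold lower number from compound 2 to compound 3 (0.03 log units; within the scatter)), so joining the same three carbons differently has no readable effect here. The longer straight chain of compound 3 can also be set against the methyl of compound 1 (a 1.6-fold lower number from compound 1 to compound 3 (0.21 log units; within the scatter)), and this wider change stays within the scatter too, so methyl, isopropyl and propyl on this oxygen cannot be put in order. No measured evidence is available to explain this result.

The compounds shown leave open whether a chain longer than propyl, such as butyl or hexyl, would move the number beyond the scatter. They also leave open what a chain carrying an amine or a carboxylic acid would do at this oxygen.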